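The source may hold more compounds than are shown below. What is called first, only, known or untested is meant among the compounds shown, and "the series" means these compounds.

For the measured compounds named here, compound 2, `Cc1ccnc(C(=O)Nc2nn[nH]n2)c1`, is the weaker of the two compounds measured so far. In a functional assay on the whole organism for inhibition, with Rattus norvegicus as the target, at a dose of 1 mg/kg by the oral route (a higher number here means a stronger effect of the compound at the dose given, a lower number a weaker effect), compound 2 gives 28%. Compound 1, `Cc1cc(Cl)cc(C(=O)Nc2nn[nH]n2)n1`, stands higher: in this assay compound 1 gives 66%, and the gap between the two lies beyond the scatter of repeated measurements. Compound 1 carries a chloro group that compound 2 lacks, but the two structures also differ in other ways, so that gap cannot be tied to a single change.

Compound 3, `O=C(Nc1nn[nH]n1)c1cc(Cl)ccn1`, has not yet been tested in this assay. It differs from compound 2 in one place: chloro in place of methyl on an aromatic carbon.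

Going by the values given here, no pair of measured compounds differing in just one place is available, so the size of this step is uncertain. Among the compounds with values here, compound 1, the only measured compound with a chloro group, gives 66% in this assay, which leaves room for an increase. Compound 3 is therefore expected to reach about 42%, within a range of 18% to 66%. The expected step of a number 14 percentage points higher from compound 2 to compound 3 (beyond the scatter) is a moderate rise, though it may not clearly exceed the scatter.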

Compound 3, a percentage reported as inhibition, in the whole organism at one dose (the size of the read-out at that dose, not a potency): 38%
For compound 3 the middle estimate is 4 percentage points above the measured one; measured number inside the range.
By their numbers in this assay, from the lowest: compounds 2 and 3 (each within the scatter of the next); then compound 1.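

In this assay, putting chloro in place of methyl on this aromatic carbon, opposite the ring nitrogen, gives a number 10 percentage points higher from compound 2 to compound 3 (within the scatter), so at this position the two groups cannot be told apart on these numbers. For the compounds shown here, the other step is the first single change to clear the scatter: hydrogen in place of the methyl that compound 1 carries on an aromatic carbon gives a number 28 percentage points lower from compound 1 to compound 3 (beyond the scatter), which shows that the chloro group alone does not bring the higher number of compound 1, since compound 3 keeps that chloro and still falls well short once the methyl is gone. Nothing measured here explains why that methyl makes such a difference to the effect at this oral dose.

Still open is whether the methyl step would be as large without the chloro, since a compound carrying hydrogen in place of the chloro of compound 3 is not among those shown. Also open, going by these compounds, is how other groups would behave at either place, for example a methoxy group or an amine on the aromatic carbon that holds the chloro, or an ethyl chain in place of the methyl of compound 1.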